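This account rests on a few compounds, and the source may have more. Where it says the series, first, only, none or still open, it means among the compounds named here.

In a functional assay on Sf9 cells for antagonist activity at histamine H2 receptor (Homo sapiens), with stated times of 2 min and 20 min (on this read-out higher numbers stand for higher potency (the scale is a negative logarithm) and lower numbers for lower potency), compound 1, whose structure is `CC(CC(=O)/N=C(\N)NCCCc1ccccc1)c1ccccc1`, gives 5.89. Compound 2, `N/C(=N\C(=O)CC(c1ccccc1)c1ccccc1)NCCCc1ccccc1`, carries one change against compound 1, (phenyl in place of methyl on a saturated chain carbon bound to an aromatic carbon and a saturated chain carbon), and in this assay compound 2 gives 5.89. The step that this change made is no change at the digits printed from compound 1 to compound 2 (within the scatter). Compound 3, `CC(CC(=O)/N=C(\N)NCCCn1ccnc1)c1ccccc1`, differs from compound 1 in its core, (1H-imidazol-1-yl in place of phenyl on a saturated chain carbon, three bonds along the chain from an amine nitrogen). For compound 3 the read-out in this assay is only a limit of the assay, < 5. The step from compound 1 is therefore known only as a bound, a number at least 0.89 log units lower from compound 1 to compound 3 (beyond the scatter), because of the limit of < 5 in this assay, at which 1 of the 3 values shown sits.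

Compound 4, `N/C(=N\C(=O)CC(c1ccccc1)c1ccccc1)NCCCn1ccnc1`, which has not been measured, stands to compound 3 as compound 2 stands to compound 1: phenyl in place of methyl on a saturated chain carbon bound to an aromatic carbon and a saturated chain carbon. The place of the change reads the same in both pairs, so it is the same change, made on the core of compound 3 instead of the core of compound 1. For the measured compounds named here, the step from compound 3 to compound 4 in this assay is expected to be a step that the limit leaves unreadable from compound 3 to compound 4, resting on the one measured example, the step from compound 1 to compound 2, which was no change at the digits printed from compound 1 to compound 2 (within the scatter). For compound 4 the estimate in this assay is 4.7, with a range from 4.1 to 5.3.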

Compound 4, negative logarithm of the antagonist equilibrium constant: 5.82
Compound 4: the middle estimate sits 1.12 log units below what was measured; the measured number lies above the stated range.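

In this assay compound 3 gives < 5, which is a limit of the assay and not a number, so any step from it is known only as a bound. Phenyl in place of methyl did not carry over unchanged from one core to the other, with no change at the digits printed from compound 1 to compound 2 (within the scatter) set against a number at least 0.82 log units higher from compound 3 to compound 4 (beyond the scatter): the same change on two cores in this assay, no change at the digits printed (within the scatter) from compound 1 to compound 2 and a number at least 0.82 log units higher (beyond the scatter) from compound 3 to compound 4, at least 0.82 log units apart, beyond the scatter of two such steps The same holds when the change is read the other way, with 1H-imidazol-1-yl in place of phenyl, and these four compounds give neither a reason for the gap nor its exact size, with a number at least 0.89 log units lower from compound 1 to compound 3 (beyond the scatter) set against a number 0.07 log units lower from compound 2 to compound 4 (within the scatter): the same change on two cores in this assay, a number at least 0.89 log units lower (beyond the scatter) from compound 1 to compound 3 and a number 0.07 log units lower (within the scatter) from compound 2 to compound 4, at least 0.82 log units apart, beyond the scatter of two such steps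

As far as these compounds go, it remains open whether an ethyl or a cyclohexyl group in place of the methyl would act on the core of compound 3 as phenyl does. From the compounds shown here alone, it also remains open whether a pyridine ring in place of the 1H-imidazol-1-yl would show the same dependence on the other group.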